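Three Similar Values and One Untested Swap

The source may hold more compounds than are shown below. What is called first, only, known or untested is meant among the compounds shown, and "the series" means these compounds.

Results in a functional assay on CAKI-1 cells (Homo sapiens) for inhibition, read by sulforhodamine B assay, with a stated time of 48 h, tested at 10 uM (on this read-out lower numbers stand for less inhibition of growth and higher numbers for more inhibition of growth at the one concentration tested), for three compounds:
Compound 1 `CC(=O)c1ccc(Nc2ccnc(SCC(=O)c3ccc(Br)cc3)n2)cc1` gives 24%
Compound 2 `CCOC(=O)c1ccc(Nc2ccnc(SCC(=O)c3ccc([N+](=O)[O-])cc3)n2)cc1` gives 16%
Compound 3 `O=C(O)c1ccc(Nc2ccnc(SCC(=O)c3ccc(C(F)(F)F)cc3)n2)cc1` gives 19%

These three numbers lie within the usual scatter of one another, so they cannot be ranked. Compound 3 therefore sits level with both of the others. No two of them differ in just one place, which leaves no clean single-change comparison to draw on.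

Compound 4 `CC(=O)c1cccc(Nc2ccnc(SCC(=O)c3ccc(C(F)(F)F)cc3)n2)c1` differs from compound 3 in one place: it has 3-acetylphenyl in place of 4-carboxyphenyl on a nitrogen on an aromatic ring and keeps everything else.

With compound 1 at 24% and compound 3 at 19% still within the scatter although they differ in more than one place, no step beyond the scatter is expected in this assay in either direction. The estimate means an expected a number 1 percentage points higher from compound 3 to compound 4 (within the scatter) that stays within the scatter. For compound 4 the estimated growth inhibition is 20% with an expected range of 7% to 35% in this test.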

Compound 4, percent growth inhibition at one concentration: 42%
Estimate against measurement, compound 4: 22 percentage points below, and the stated range ends below it.
By their numbers in this assay, from the lowest: compounds 2, 3 and 1 (each within the scatter of the next); then compound 4.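

In this assay, among the compounds shown here, putting 3-acetylphenyl in place of 4-carboxyphenyl on the nitrogen gives a number 23 percentage points higher from compound 3 to compound 4 (beyond the scatter), the first single-change comparison in this set. It shows that growth inhibition at this one concentration can respond to what sits on this nitrogen, something the three earlier compounds, which differ in more than one place, could not show. The swap changes the group, its printed place on the phenyl ring and the hydrogen-bond donor count, going from 1 to 0, and nothing available explains which of these matters.

Still open, on these data alone, is whether the acetyl group itself or its place on the ring goes with the higher number. It is also unknown how an amine or an amide on the same phenyl ring would read here.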